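Adding a Methoxy to the Indole Ring: Expected Cytotoxicity

The source may hold more compounds than are shown below. What is called first, only, known or untested is meant among the compounds shown, and "the series" means these compounds.

Compound 1 `COc1cccc(C(=O)N2CCN(CC(=O)N3CCN(CCCc4c[nH]c5ccccc45)CC3)CC2)c1`: 143000 nM
Compound 2 `O=C(CN1CCN(C(=O)c2cccc(F)c2)CC1)N1CCN(CCCc2c[nH]c3ccccc23)CC1`: 182000 nM

In an ADME assay on HEK293 cells (Homo sapiens) for cytotoxicity, read by MTT assay, with a stated time of 72 h (on this read-out lower numbers stand for stronger inhibition and higher numbers for weaker inhibition), compound 1 holds the lowest of the two numbers, and its nearest neighbour is compound 2: a 1.3-fold higher number from compound 1 to compound 2 (0.10 log units; within the scatter). Compound 3 `COc1cccc(C(=O)N2CCN(CC(=O)N3CCN(CCCc4c[nH]c5ccc(OC)cc45)CC3)CC2)c1` differs from compound 1 in one place: methoxy in place of hydrogen on an aromatic carbon. For the measured compounds named here, no measured step touches the indole ring; the single step measured concerns the other aromatic ring and stays within the scatter, so it offers no guide. The author therefore expects no step beyond the scatter, a 1.0-fold lower number from compound 1 to compound 3 (0.01 log units; within the scatter). Compound 3 is estimated at 140000 nM, with a range from 70000 nM to 280000 nM.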

Compound 3, half-maximal inhibitory concentration: > 200000 nM
Compound 3 gave a limit, no number; the forecaster's own chance of this, stated with the estimate: 10%; middle value at least 1.4-fold (0.15 log units) away from the limit.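

For the compounds shown here, the 5-methoxy-1H-indol-3-yl group of compound 3 brings the first measured change on this ring, and in this assay it gives no sign of stronger inhibition: an at least 1.3-fold higher number from compound 1 to compound 3 (0.14 log units; that floor lies within the scatter). For compound 3, > 200000 nM is a limit of the assay and not a number. The floor of the step lies within the scatter and its true size cannot be read, the only bound being this: the limit of > 200000 nM in this assay, at which 1 of the 3 values shown sits.

From the compounds shown here alone, how far compound 3 lies past that limit stays open. So does whether an amine or a carboxylic acid at this position would give a readable number.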